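A few compounds are considered here, and "the series" means these few. Any claim that something is new, unique, unknown or untested is made for them only; others in the source may bear on it.

Of the compounds shown here, three built on one shared core have been measured. Compound 1 `O=C(NCCO)c1cc(-c2ccc(Cl)cc2Cl)n[nH]1` gives 44 nM in an assay on isolated protein for inhibition of alkaline phosphatase, tissue-nonspecific isozyme (Homo sapiens); a higher number here means a weaker inhibitor, a lower number a stronger inhibitor. Compound 2 `CN1CCN(C(=O)c2cc(-c3ccc(Cl)cc3Cl)n[nH]2)CC1` gives 828 nM in this assay, and compound 3 `O=C(c1cc(-c2ccc(Cl)cc2Cl)n[nH]1)N1CCCCCC1` gives 1450 nM. Compound 3 therefore stands at the highest number of the three: it sits furthest from compound 1, with a 33-fold higher number from compound 1 to compound 3 (1.52 log units; beyond the scatter), and nearest to compound 2, with a 1.8-fold higher number from compound 2 to compound 3 (0.24 log units; within the scatter).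

Compound 4 `O=C(c1cc(-c2ccc(Cl)cc2Cl)n[nH]1)N(CCO)CCO` differs from compound 3 in one place: bis(2-hydroxyethyl)amino in place of azepan-1-yl on a carbonyl carbon. Among the measured compounds shown here, the step that bears most directly on this change is the one between compound 1 and compound 3, where a 33-fold higher number from compound 1 to compound 3 (1.52 log units; beyond the scatter) was seen when the single (2-hydroxyethyl)amino group was exchanged for azepan-1-yl. For the measured compounds named here, compound 4 runs that exchange backwards and carries two such hydroxyethyl chains instead of one, so a clearly lower number in this assay is expected, though no measured pair shows what the second chain itself does. Compound 4 is estimated at 150 nM, with a range from 40 nM to 600 nM, which would mean an expected step of a 9.7-fold lower number from compound 3 to compound 4 (0.99 log units; beyond the scatter).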

Compound 4, half-maximal inhibitory concentration: 47 nM
Compound 4: the middle estimate sits 3.2-fold (0.50 log units) above what was measured, and the stated range covers the measured number.
By their numbers in this assay, from the lowest: compounds 1 and 4 (each within the scatter of the next); then compounds 2 and 3 (each within the scatter of the next).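

In this assay, bis(2-hydroxyethyl)amino on the carbonyl carbon brings a 31-fold lower number from compound 3 to compound 4 (1.49 log units; beyond the scatter) when it replaces azepan-1-yl and an 18-fold lower number from compound 2 to compound 4 (1.25 log units; beyond the scatter) when it replaces 4-methylpiperazin-1-yl, so the low number does not belong to compound 1 alone. Putting a 2-hydroxyethyl chain in place of the amide hydrogen gives a 1.1-fold higher number from compound 1 to compound 4 (0.03 log units; within the scatter) and shows that, in this pair, the amide hydrogen is not needed to keep the number low and the second chain brings no readable change. Nothing shown here explains why these chains give such different numbers from the two rings.

Whether the hydroxyl group itself counts, or only the open chain, stays unsettled, and a 2-methoxyethyl or plain ethyl chain on the amide nitrogen would help separate the two. Also open, on these data alone, is how a longer chain such as 3-hydroxypropyl, or a ring carrying a hydroxyl such as 4-hydroxypiperidin-1-yl, would behave.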